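Fluoro entry on the aryl sulfone of compound 1

A few compounds are considered here, and "the series" means these few. Any claim that something is new, unique, unknown or untested is made for them only; others in the source may bear on it.

Measured in an assay on isolated protein for displacement of a labelled ligand from metabotropic glutamate receptor 5 (Homo sapiens), with a stated time of 60 min, tested at 1 uM; a lower number here means less inhibition, a higher number more inhibition at the concentration tested (going by the name of the read-out):
- compound 1, `COc1ccc2ncc(S(=O)(=O)c3ccc(C)cc3)c(N3CCC(C)CC3)c2c1`: 90%
- compound 2, `Cc1ccc(S(=O)(=O)c2cnc3ccc(Cl)cc3c2N2CCC(C)CC2)cc1`: 95%

Compound 1 has the lowest of the two numbers in this assay. For the measured compounds named here, its nearest neighbour is compound 2, and the only measured step, a number 5 percentage points higher from compound 1 to compound 2 (within the scatter), is within the scatter, so the two cannot be ranked.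

The unmeasured compound 3, `COc1ccc2ncc(S(=O)(=O)c3ccc(C)c(F)c3)c(N3CCC(C)CC3)c2c1`, differs from compound 1 by fluoro in place of hydrogen on an aromatic carbon. Going by the values given here, this change sits on the 4-methylphenyl ring of the sulfone, whereas the one measured step, a number 5 percentage points higher from compound 1 to compound 2 (within the scatter), concerns the other aromatic ring of the shared core. Among the compounds with values here, no measured step therefore bears directly on the new change; the only information is that the one exchange on the core made so far leaves the number in this assay within the scatter of compound 1.

On that basis no step beyond the scatter is expected for compound 3, the estimated step being a number 2 percentage points lower from compound 1 to compound 3 (within the scatter). Compound 3 is estimated to give 88% in this assay, expected between 75% and 97%.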

Compound 3, a percentage reported as inhibition, at one concentration (the size of the read-out at that concentration, not a potency): 73%
Compound 3: the middle estimate sits 15 percentage points above what was measured; the whole stated range lies above it.
By their numbers in this assay, from the lowest: compound 3; then compounds 1 and 2 (each within the scatter of the next).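

In this assay, the sulfone aryl ring proves sensitive to a single-atom change: going from 4-methylphenyl to 3-fluoro-4-methylphenyl, with fluoro in place of hydrogen on an aromatic carbon ortho to the methyl group, gives a number 17 percentage points lower from compound 1 to compound 3 (beyond the scatter). For the compounds shown here, the earlier exchange of methoxy for chloro, on the other aromatic ring of the shared core, gave only a number 5 percentage points higher from compound 1 to compound 2 (within the scatter), so this is the first step to exceed the scatter, and it lies on the sulfone side. Nothing measured on these compounds accounts for this lower number.

The compounds shown leave open whether the drop is specific to fluoro or would also follow from another group on the same carbon, such as chloro, methoxy or an amine. They also leave open whether the same fluoro exchange gives a similar step on the chloro-bearing core of compound 2, and how the ring responds when the neighbouring methyl group gives way to an ethyl group or to hydrogen.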